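Acetyl for isopropyl on the anilide ring of compound 2

A few compounds are considered here, and "the series" means these few. Any claim that something is new, unique, unknown or untested is made for them only; others in the source may bear on it.

The set comprises compound 1 `CCc1cccc(NC(=O)N[C@H](C)c2ccccc2)c1`, compound 2 `CC(C)c1ccccc1NC(=O)N[C@H](C)c1ccccc1` and compound 3 `CC(C)c1ccccc1NC(=O)N[C@@H](C)c1ccccc1`, all measured in an ADME assay on the whole organism with Oryza sativa as the target, tested at 1 uM; on this read-out lower numbers stand for a stronger effect and higher numbers for a weaker effect at the one concentration tested. Compound 1 gives 71%, compound 2 gives 101% and compound 3 gives 96%. Compound 2 and compound 3 cannot be told apart, since a number 5 percentage points lower from compound 2 to compound 3 (within the scatter), which is consistent with the fact that compounds 2 and 3 differ only in the configuration as drawn; compound 1 alone stands apart, with the lowest of the three numbers.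

The step from compound 2 to compound 4 `CC(=O)c1ccccc1NC(=O)N[C@H](C)c1ccccc1` brings (acetyl in place of isopropyl on an aromatic carbon). Within the data shown here, the only measured step, the one from compound 2 to compound 3, changes configuration alone and says nothing about replacing one substituent with another on the aromatic ring. Among the measured compounds shown here, no measured step therefore bears on this change, and the expected size of the step in this assay is undetermined rather than none.

Compound 4 is accordingly estimated near the value of compound 2, at 88%, within a wide range from 55% to 110%, which corresponds to an expected step of a number 13 percentage points lower from compound 2 to compound 4 (beyond the scatter).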

Compound 4, a percentage reported as activity, at one concentration (the size of the read-out at that concentration, not a potency): 95%
Estimate against measurement, compound 4: 7 percentage points below; the range from low to high includes it.
By their numbers in this assay, from the lowest: compound 1; then compounds 4, 3 and 2 (each within the scatter of the next).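

Replacing isopropyl with acetyl on an aromatic carbon, ortho to a large group, gives a number 6 percentage points lower from compound 2 to compound 4 (within the scatter) in this assay. The earlier compounds shown here showed only a change of configuration, whereas this step shows that a group of carbon alone can give way to one carrying a hydrogen-bond acceptor and a double bond outside the aromatic ring with no change in the read-out that stands clear of the scatter. Nothing at hand speaks to why the two groups read alike.

The compounds shown leave open whether an amine, a carboxylic acid or a longer chain on this aromatic carbon would read the same way in this assay. Also open, from the compounds shown here alone, is how the acetyl group reads with the stereocentre drawn S, the configuration of compound 3.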